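A few compounds are considered here, and "the series" means these few. Any claim that something is new, unique, unknown or untested is made for them only; others in the source may bear on it.

Compound 1 `CC1=NN(S(=O)(=O)c2ccccc2)C(c2cc(Br)ccc2O)C1`: > 60000 nM
Compound 2 `CC1=NN(S(=O)(=O)c2ccc(F)cc2)C(c2cc(Br)ccc2O)C1`: 15500 nM

In a functional assay on MGC-803 cells (Homo sapiens) for antiproliferative activity, read by MTT assay, with a stated time of 48 h (a lower number here means that less compound is needed, a higher number that more compound is needed for the effect), compound 1 gives > 60000 nM, which is a limit. Compound 2 gives 15500 nM, the only number shown so far. Compound 3 `COc1ccc(S(=O)(=O)N2N=C(C)CC2c2cc(Br)ccc2O)cc1` carries methoxy in place of fluoro on an aromatic carbon, methoxy in place of fluoro on an aromatic carbon, para to a large group. Among the measured compounds shown here, the one measured step bearing on this is an at least 3.8-fold lower number from compound 1 to compound 2 (0.58 log units; beyond the scatter), beyond the scatter, and it rests on (the limit of > 60000 nM in this assay, at which 1 of the 2 values shown sits). Losing the fluoro may give back part of that step, so a modest move to a higher number is expected in this assay. For compound 3 the estimate is 22000 nM, with an expected range from 8000 nM to 60000 nM. This estimate means a 1.4-fold higher number from compound 2 to compound 3 (0.15 log units; within the scatter).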

Compound 3, half-maximal effective concentration: 20300 nM
Compound 3: the middle estimate sits 1.1-fold (0.03 log units) above what was measured, within the range that was stated.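

In this assay, the place para to a large group accepts a methoxy as well as a fluoro, and the two cannot be told apart, with a 1.3-fold higher number from compound 2 to compound 3 (0.12 log units; within the scatter). Methoxy in place of hydrogen gives an at least 2.9-fold lower number from compound 1 to compound 3 (0.47 log units; beyond the scatter), so two different groups at this place now go with a lower number than hydrogen. The true size of that step stays unknown, as it rests on a limit: the limit of > 60000 nM in this assay, at which 1 of the 3 values shown sits.

The compounds shown leave open whether an amine or a carboxylic acid at this place would keep the lower number.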